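Compound 2 to compound 4: fluoro on the phenyl

A few compounds are considered here, and "the series" means these few. Any claim that something is new, unique, unknown or untested is made for them only; others in the source may bear on it.

Among the compounds with values here, in a functional assay on MCF7 cells (Homo sapiens) for cytotoxicity, read by MTT assay, with a stated time of 48 h (on this read-out lower numbers stand for stronger inhibition and higher numbers for weaker inhibition), compound 2 (`C=C1OC(=O)C=C1Cc1ccc(NC(=O)/C=C/c2ccccc2)cc1`) gives 9490 nM, the only exact number so far. Compound 1 (`O=C(/C=C/c1ccccc1F)Nc1ccc(CC2=CC(=O)OC2)cc1`) reads > 50000 nM, which is a limit. Compound 3 (`C=C1OC(=O)C=C1Cc1ccc(NC(=O)c2ccccc2)cc1`) reads > 50000 nM, which is also a limit. Compound 2 therefore has no exact value to be ranked against.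

Compound 4 (`C=C1OC(=O)C=C1Cc1ccc(NC(=O)/C=C/c2ccc(F)cc2)cc1`) departs from compound 2 by a single change: fluoro in place of hydrogen on an aromatic carbon. In words, this is fluoro in place of hydrogen on an aromatic carbon, phenyl to 4-fluorophenyl.

Within the data shown here, the one measured step is an at least 5.2-fold higher number from compound 2 to compound 3 (0.72 log units; beyond the scatter), with phenyl in place of 2-phenylethenyl on a carbonyl carbon. That step is beyond the scatter, but it is a different kind of change and gives no direct size for this one. Among the measured compounds shown here, no measured step covers the fluoro change, so no shift beyond the scatter is expected in this assay, and no direction is favoured. The estimated step is a 1.1-fold higher number from compound 2 to compound 4 (0.02 log units; within the scatter). For compound 4 the expected value is 10000 nM, with an estimated range of 4500 nM to 25000 nM.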

Compound 4, half-maximal inhibitory concentration: 4430 nM
The estimate for compound 4 lay 2.3-fold (0.35 log units) above the measured number; measured number outside the range, below it.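

Fluoro in place of hydrogen gives a 2.1-fold lower number from compound 2 to compound 4 (0.33 log units; beyond the scatter) in this assay. The earlier step replaced the whole 2-phenylethenyl group on the carbonyl carbon, whereas this one shows that a single fluorine atom, on an aromatic carbon para to a large group, is enough to move the number beyond the scatter and in the lower direction. Compound 2 and compound 4 are also the only pair in the series with exact numbers at both ends: the limit of > 50000 nM in this assay, at which 2 of the 4 values shown sit.

From the compounds shown here alone, whether this shift is particular to fluoro stays open, and chloro, methoxy or an amine on the same aromatic carbon would test that. Compound 1 also carries a fluoro but differs from compound 4 in more than one place, so it cannot be read against it.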